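Sulfonamide aryl variation on a shared benzofuran-free core series

The source may report more compounds than this note shows. Statements on the series, on what has been measured and on what is new or still open speak of the compounds shown alone.

Two members of this series carry a sulfonamide bearing a substituted phenyl ring on the sulfonyl sulfur. Compound 1 `CCOC(=O)c1oc2ccc(NS(=O)(=O)c3cccc(C(F)(F)F)c3)cc2c1C` carries a trifluoromethyl-substituted phenyl; compound 2 `CCOC(=O)c1oc2ccc(NS(=O)(=O)c3ccc([N+](=O)[O-])cc3)cc2c1C` carries a 4-nitrophenyl. In a functional assay on MDA-MB-468 cells (Homo sapiens) for antiproliferative activity, read by MTT assay, with a stated time of 72 h (a higher number here means a weaker inhibitor, a lower number a stronger inhibitor), compound 2 gives 24000 nM, and compound 1 gives 28900 nM; the two numbers lie within the usual scatter of each other, so the two compounds cannot be told apart on this assay. Both are weak.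

Compound 3 `CCOC(=O)c1oc2ccc(NS(=O)(=O)c3cccc([N+](=O)[O-])c3)cc2c1C` has not been measured. Its change from compound 2 is 3-nitrophenyl in place of 4-nitrophenyl on a sulfonyl sulfur. Since the two measured compounds, which differ in what sits on the sulfonyl phenyl, return numbers within the scatter, no step beyond the scatter is expected in this assay from compound 2 to compound 3, and a 1.1-fold higher number from compound 2 to compound 3 (0.05 log units; within the scatter) is taken as flat. Compound 3 is therefore expected to give 27000 nM, within a range from 12000 nM to 60000 nM.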

Compound 3, half-maximal inhibitory concentration: 30100 nM
Estimate against measurement, compound 3: 1.1-fold (0.05 log units) below, and the stated range covers the measured number.
By their numbers in this assay, from the lowest: compounds 2, 1 and 3 (each within the scatter of the next).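

In this assay, 3-nitrophenyl in place of 4-nitrophenyl on a sulfonyl sulfur gives a 1.3-fold higher number from compound 2 to compound 3 (0.10 log units; within the scatter), so this exchange of nitrophenyl isomers does not separate the two compounds. Nitro in place of trifluoromethyl on an aromatic carbon gives a 1.0-fold higher number from compound 1 to compound 3 (0.02 log units; within the scatter), a single-place comparison that the earlier pair, which differed in more than one place, could not provide, and it too leaves the compounds indistinguishable. No measured property of these groups is available to bear on this flat result.

On these data alone, whether an amine, a carboxylic acid or a longer chain on the sulfonyl phenyl ring would give a step beyond the scatter remains open. Also open, as far as these compounds go, is whether anything other than the ethyl ester on the shared core would change the read-out.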